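Replacing the (4-chlorobenzyl)amino Group on a Shared Core

This account rests on a few compounds, and the source may have more. Where it says the series, first, only, none or still open, it means among the compounds named here.

Three amides built on one shared core have been tested in a functional assay on MCF7 cells (Homo sapiens) for antiproliferative activity, read by sulforhodamine B assay, with a stated time of 48 h (a higher number here means a weaker inhibitor, a lower number a stronger inhibitor), so far. Compound 1 (`COc1ccc(C[C@@H](O)/C=C/C=C/C(=O)NCc2ccc(Cl)cc2)cc1OC`) gives 18100 nM in this test. Compound 2 (`COc1ccc(C[C@@H](O)/C=C/C=C/C(=O)N2CCN(C(c3ccccc3)c3ccccc3)CC2)cc1OC`) gives 12500 nM and compound 3 (`COc1ccc(C[C@@H](O)/C=C/C=C/C(=O)NCc2cc(OC)c(OC)c(OC)c2)cc1OC`) gives 15300 nM in the same test. Compound 1 therefore stands level with the other two: its number lies within the scatter of both, and the three cannot be ranked.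

Compound 4 (`COc1ccc(C[C@@H](O)/C=C/C=C/C(=O)N2CCCC2)cc1OC`) has not yet been measured. The change from compound 1 to compound 4 is pyrrolidin-1-yl in place of (4-chlorobenzyl)amino on a carbonyl carbon and it puts pyrrolidin-1-yl in place of (4-chlorobenzyl)amino on a carbonyl carbon.

No measured pair of these compounds differs in one place only, so the size of this step in this assay cannot be read directly. The expectation rests on compound 2 at 12500 nM and compound 3 at 15300 nM as well as on compound 1 at 18100 nM. These values stay within the scatter of one another despite their different amide parts. The estimated move is a 1.1-fold higher number from compound 1 to compound 4 (0.04 log units; within the scatter) and it is expected to stay within the scatter, with no firm direction. Compound 4 is expected at 20000 nM with an estimated range from 9000 nM to 45000 nM in this measurement.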

Compound 4, half-maximal inhibitory concentration: 26200 nM
Estimate against measurement, compound 4: 1.3-fold (0.12 log units) below; the range from low to high includes it.
By their numbers in this assay, from the lowest: compounds 2, 3, 1 and 4 (each within the scatter of the next, the first and the last beyond it).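

In this assay, among the compounds shown here, the one step that can be read at this position, on a carbonyl carbon, is a 1.4-fold higher number from compound 1 to compound 4 (0.16 log units; within the scatter), with pyrrolidin-1-yl in place of (4-chlorobenzyl)amino. This step removes the six-membered aromatic ring, the chlorine and the amide hydrogen all at once, yet compound 4 cannot be told apart from compound 1 in this test, so none of these features is shown to matter at this position on the evidence of this pair. Nothing measured here explains this result, and the reading of this step rests on these two numbers alone.

The compounds shown leave open how the parts of this change contribute on their own, since only a group such as benzylamino without the chlorine, or dimethylamino, or piperidin-1-yl on the same carbonyl carbon would separate the loss of the chlorine, the aromatic ring and the amide hydrogen. They also leave open whether an amide part carrying a free amine or a carboxylic acid would move the number beyond the scatter from compound 1.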